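The source may report more compounds than this note shows. Statements on the series, on what has been measured and on what is new or still open speak of the compounds shown alone.

Going by the values given here, in a functional assay on PC-3M cells (Homo sapiens) for inhibition, read by sulforhodamine B assay (on this read-out lower numbers stand for stronger inhibition and higher numbers for weaker inhibition), compound 2 `NCC1CCN(c2ncnc3[nH]ccc23)CC1` gives 32000 nM, the higher of the two numbers so far. Among the compounds with values here, its only neighbour, compound 1 `NCC1(Cc2ccc(Cl)cc2)CCN(c2ncnc3[nH]ccc23)CC1`, gives 15000 nM. Compound 3 `NC(c1ccc(Cl)cc1)C1CCN(c2ncnc3[nH]ccc23)CC1` keeps the shared core and differs from compound 2 as follows: 4-chlorophenyl in place of hydrogen on a saturated chain carbon bound to an amine nitrogen and a saturated ring carbon. Within the data shown here, one measured step bears on this change: a 2.1-fold higher number from compound 1 to compound 2 (0.33 log units; beyond the scatter), in which hydrogen replaces 4-chlorobenzyl on a saturated ring carbon. Read in reverse, this modest step pairs the chlorinated group with the lower number. In compound 3, however, 4-chlorophenyl sits on a saturated chain carbon bound to an amine nitrogen and a saturated ring carbon, and a single pair establishes no pattern. A similarly modest move towards a lower number in this assay is therefore expected, with low confidence in its direction. The estimated step is a 2.3-fold lower number from compound 2 to compound 3 (0.36 log units; beyond the scatter). For compound 3, the expected value is 14000 nM, with an estimated range of 4000 nM to 40000 nM.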

Compound 3, half-maximal inhibitory concentration: 7400 nM
Compound 3: the middle estimate sits 1.9-fold (0.28 log units) above what was measured, and the stated range covers the measured number.
By their numbers in this assay, from the lowest: compound 3; then compound 1; then compound 2.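

Measured in this assay the change from hydrogen to 4-chlorophenyl on a saturated chain carbon bound to an amine nitrogen and a saturated ring carbon gives a 4.3-fold lower number from compound 2 to compound 3 (0.64 log units; beyond the scatter) and shows that a chlorinated aromatic group can go with a lower number at this place too, not only as the 4-chlorobenzyl of compound 1. Both steps start from compound 2, so they show the same direction at two places in this small set and establish no general pattern. Nothing measured accounts for the lower number at this position.

The compounds shown leave open whether the chlorine contributes to this step, which a plain phenyl or a 4-methoxyphenyl on the same carbon would test. They also leave open how a hydroxyl group in place of the amine would read at this carbon.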